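Swapping chloro for methoxy on the shared core

The source may report more compounds than this note shows. Statements on the series, on what has been measured and on what is new or still open speak of the compounds shown alone.

Compound 1 `CCCCNc1ccnc2cc(Cl)ccc12`: 9550 nM
Compound 2 `CCCCNc1ccnc2cc(F)ccc12`: 3170 nM
Compound 3 `CN(C)CCNc1ccnc2cc(Cl)ccc12`: 7540 nM

Of the compounds shown here, three sharing one core have been tested in a functional assay on MCF7 cells (Homo sapiens) for cytotoxicity, read by sulforhodamine B assay, with a stated time of 48 h, in the presence of a further agent that is not named here; a lower number here means a stronger inhibitor of growth, a higher number a weaker inhibitor of growth. Compound 3 `CN(C)CCNc1ccnc2cc(Cl)ccc12` gives 7540 nM, the second highest of the three numbers; its number sits within the scatter of compound 1, which gives 9550 nM, while compound 2, which gives 3170 nM, lies clearly lower.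

Compound 4 `COc1ccc2c(NCCN(C)C)ccnc2c1` has not yet been measured. It differs from compound 3 in one place: methoxy in place of chloro on an aromatic carbon.

Of the measured steps, only one touches the same aromatic position. There, a 3.0-fold lower number from compound 1 to compound 2 (0.48 log units; beyond the scatter), a modest lowering of the number. The other step, a 1.3-fold lower number from compound 1 to compound 3 (0.10 log units; within the scatter), concerns the chain and has no bearing here. Methoxy has not been tried at this position in any measured compound, so the direction is uncertain; the one change at that position lowered the number, and a similar or smaller shift is expected for compound 4, with a real chance of no step beyond the scatter.

For compound 4 in this assay the estimate is 5000 nM, with a range from 2000 nM to 15000 nM, which would mean an expected step of a 1.5-fold lower number from compound 3 to compound 4 (0.18 log units; within the scatter).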

Compound 4, concentration for 50% growth inhibition: 2650 nM
For compound 4 the middle estimate is 1.9-fold (0.28 log units) above the measured one, within the range that was stated.
By their numbers in this assay, from the lowest: compounds 4 and 2 (each within the scatter of the next); then compounds 3 and 1 (each within the scatter of the next).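

Methoxy in place of chloro on this aromatic carbon gives a 2.8-fold lower number from compound 3 to compound 4 (0.45 log units; beyond the scatter) in this assay and so shows that a step beyond the scatter at this position is not confined to fluoro or to the butylamino compounds, since this pair carries the dimethylamino chain. Among these compounds, until now the only reading here was a 3.0-fold lower number from compound 1 to compound 2 (0.48 log units; beyond the scatter) on the other chain; chloro now has the higher number in both pairs that differ at this position, and neither of these pairs goes against that, though two pairs make only a narrow pattern. The change adds one heavy atom and one hydrogen-bond acceptor, but nothing shown links either count to the lower number, and no measurement here accounts for the shift.

Compound 2 and compound 4 differ in two places, so the shared core and these values do not settle how fluoro and methoxy rank against each other on a single chain. Also open, as far as these compounds go, is how an amine or a carboxylic acid on this aromatic carbon would behave, and whether a longer chain would leave the effect of this swap intact.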